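The source may report more compounds than this note shows. Statements on the series, on what has been measured and on what is new or still open speak of the compounds shown alone.

Of the compounds shown here, three have been measured in a functional assay on A549 cells (Homo sapiens) for antiproliferative activity, read by MTT assay, with a stated time of 72 h; a higher number here means a weaker inhibitor, a lower number a stronger inhibitor. Compound 1 `COc1cc2ncnc(N3CCc4ccccc43)c2cc1NC(=O)C=C(C)C` gives 6270 nM in this assay. Differing from compound 1 by prop-1-en-1-yl in place of 2-methylprop-1-en-1-yl on a carbonyl carbon, compound 2 `C/C=C/C(=O)Nc1cc2c(N3CCc4ccccc43)ncnc2cc1OC` gives 8290 nM. The step for this change, a 1.3-fold higher number from compound 1 to compound 2 (0.12 log units; within the scatter), is small. Compound 3 `CC(C)=CC(=O)Nc1cc2c(N3CCCc4ccccc43)ncnc2cc1O[C@@H]1CCOC1` gives 7910 nM in this assay. The difference between the core of compound 1 and the core of compound 3 is not broken down here. Compound 4 `C/C=C/C(=O)Nc1cc2c(N3CCCc4ccccc43)ncnc2cc1O[C@@H]1CCOC1` has not yet been measured. It differs from compound 3 by prop-1-en-1-yl in place of 2-methylprop-1-en-1-yl on a carbonyl carbon, the same change, made at the same place, as that from compound 1 to compound 2. Because a 1.3-fold higher number from compound 1 to compound 2 (0.12 log units; within the scatter) stayed within the usual scatter, a step of similar size is expected here, a 1.3-fold higher number from compound 3 to compound 4 (0.10 log units; within the scatter). Compound 4 is therefore estimated at 10000 nM, with a likely range from 5000 nM to 20000 nM.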

Compound 4, half-maximal inhibitory concentration: 10800 nM
Beside the measured number, compound 4's estimate is 1.1-fold (0.03 log units) below it; the range from low to high includes it.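

Putting prop-1-en-1-yl in place of 2-methylprop-1-en-1-yl on the carbonyl carbon gives a 1.4-fold higher number from compound 3 to compound 4 (0.14 log units; within the scatter) in this assay, and the step matches the one seen on the other core: the same change on two cores in this assay, a 1.3-fold higher number (0.12 log units; within the scatter) from compound 1 to compound 2 and a 1.4-fold higher number (0.14 log units; within the scatter) from compound 3 to compound 4, 1.0-fold (0.01 log units) apart, within the scatter of two such steps. In these two pairs, then, the change carried from one core to the other with a step of the same size. Each step lies within the scatter, however, so neither shows that the change has a real effect on the number, and two pairs cannot speak for other cores.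

The compounds shown leave open how a different group on this carbonyl carbon would read, such as a plain ethenyl group or a longer chain ending in an amine. They also leave open whether any such group would give a step beyond the scatter.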